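Notes on a pyrrolidine substituent change, mouse microsome stability

The source may hold more compounds than are shown below. What is called first, only, known or untested is meant among the compounds shown, and "the series" means these compounds.

Measured compounds:
compound 1 `COc1ccc(-c2c(C)sc3c(N4CC[C@@H](NC(C)=O)C4)nc(C)nc23)cc1OC`; in an ADME assay on microsomes from liver (Mus musculus) for metabolic stability, read by LC-MS, with NADPH named in the record, with a stated time of 60 min, tested at 1 uM, in the absence of a further agent (a lower number here means that less of the compound is left, a higher number that more of the compound is left), compound 1 reports only a limit, > 95%.
compound 2 `COc1ccc(-c2c(C)nc3c(N4CC[C@@H](NC(C)=O)C4)cc(C)nn23)cn1`; in this assay compound 2 reports only a limit, > 95%.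
compound 3 `COc1ccc(-c2c(C)nc3c(N4CC[C@@H](NC(=O)c5ccccc5)C4)cc(C)nn23)cc1OC`; in this assay compound 3 reports only a limit, > 95%.

Compound 3 stands at a limit of the assay and not at a number, and the same holds for the other two compounds, since all three sit at the limit of > 95% in this assay, at which 3 of the 3 values shown sit. Among the compounds with values here, no order among the three can therefore be read from these values, and no pair of measured compounds differs in one place only, so no measured step size is available to build on.

The next compound is compound 4 `COc1ccc(-c2c(C)nc3c(N4CC[C@@H](O)C4)cc(C)nn23)cc1OC`. It differs from compound 3 by hydroxy in place of benzamido on a saturated ring carbon. With every value shown sitting at the limit, the starting point is as high as the assay reports, and the change leaves the shared core untouched. The step is expected to be none beyond the scatter, or at most a small move downwards, as a number at least 5 percentage points lower from compound 3 to compound 4 (that floor lies within the scatter). For compound 4 the estimate is 90%, with a range from 75% to 98%.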

Compound 4, percent of the compound remaining: > 95%
Compound 4: a limit, no number; the forecaster's own chance of this, stated with the estimate: 55%; middle value at least 5 percentage points away from the limit.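

No step from compound 3 to compound 4 can be read, since both compounds report only a limit in this assay: the limit of > 95% in this assay, at which 4 of the 4 values shown sit.

Any order among the four compounds stays open, as does the size of any effect of exchanging benzamido for hydroxy on the percent of compound remaining; none of the values shown is a number.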